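Swapping amino for methoxy on a chalcone-like pyrazole

The compounds below may be only part of what the source reports. "The series", "measured", "known", "first", "only" and "open" are said of these compounds alone.

Compound 1 `COc1cc(-c2cc(/C=C/C(=O)c3ccc(N)cc3)[nH]n2)cc(OC)c1OC` is tested in a functional assay on MDA-MB-435 cells (Homo sapiens) for cytotoxicity, read by sulforhodamine B assay, with a stated time of 48 h, tested at 0.1 uM (on this read-out higher numbers stand for a weaker effect at the one concentration tested and lower numbers for a stronger effect), and gives 95%. Two close relatives have also been measured: compound 2 `COc1ccc(-c2cc(/C=C/C(=O)c3ccc(N)cc3)[nH]n2)cc1OC` gives 98% and compound 3 `COc1ccc(-c2cc(/C=C/C(=O)c3ccc(N)cc3)[nH]n2)cc1` gives 103%. Both steps between them, a number 3 percentage points higher from compound 1 to compound 2 (within the scatter) and a number 5 percentage points higher from compound 2 to compound 3 (within the scatter), stay within the scatter, so the three measured compounds cannot be told apart, and compound 1 stands among them rather than apart from them.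

Compound 4 `COc1ccc(C(=O)/C=C/c2cc(-c3cc(OC)c(OC)c(OC)c3)n[nH]2)cc1` has not been measured. It differs from compound 1 in one place: methoxy in place of amino on an aromatic carbon. Neither measured step touches this part of the molecule; both concern methoxy groups on the other aromatic ring, and both were small. The measured compounds therefore offer no reason to expect a shift beyond the scatter here. The estimate for compound 4 is 97%, with an expected range from 85% to 108%, which corresponds to an expected step of a number 2 percentage points higher from compound 1 to compound 4 (within the scatter).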

Compound 4, a percentage reported as activity, at one concentration (the size of the read-out at that concentration, not a potency): 95%
Compound 4: middle estimate off by 2 percentage points, on the high side, within the range that was stated.
By their numbers in this assay, from the lowest: compounds 1, 4, 2 and 3 (each within the scatter of the next).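

Within the data shown here, the earlier compounds varied only the methoxy groups on the other aromatic ring, so this is the first reading at the position para to a large group on the ring that carries the amino group. In this assay, among these compounds, the change from 4-aminophenyl to 4-methoxyphenyl gives no change at the digits printed from compound 1 to compound 4 (within the scatter) even though a hydrogen-bond donor leaves with the amino group, so at the one concentration tested this swap makes no visible difference. Nothing available explains this result or links it to any measured property of either group.

Going by these compounds, whether a hydroxy group, a chlorine atom or a carboxylic acid at this position would move the number beyond the scatter stays open. Also open, on these data alone, is whether compound 1 and compound 4 would still match at other concentrations.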